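This account rests on a few compounds, and the source may have more. Where it says the series, first, only, none or still open, it means among the compounds named here.

Three compounds share a core and differ only at one position. In a functional assay for inhibition, tested at 20 ug/mL (a higher number here means a stronger effect of the compound at the concentration tested, a lower number a weaker effect), compound 1 `COc1cc(-c2cc(-c3cc(C(C)C)c(O)cc3C)[nH]c(=O)c2C#N)cc(OC)c1OC` gives 35%, compound 2 `Cc1cc(O)c(C(C)C)cc1-c1cc(-c2cccs2)c(C#N)c(=O)[nH]1` gives 26%, and compound 3 `COc1ccc(-c2cc(-c3cc(C(C)C)c(O)cc3C)[nH]c(=O)c2C#N)c(OC)c1` gives 27%. On the numbers shown compound 3 stands second of three, nearest compound 2 and furthest from compound 1, yet each gap lies within the scatter. Compound 4 `Cc1cc(O)c(C(C)C)cc1-c1cc(-c2ccccc2[N+](=O)[O-])c(C#N)c(=O)[nH]1` differs from compound 3 by 2-nitrophenyl in place of 2,4-dimethoxyphenyl on an aromatic carbon. Among the measured compounds shown here, the one measured step at this position, a number 1 percentage points higher from compound 2 to compound 3 (within the scatter), was within the scatter, so the data give little reason to expect movement. The step from compound 3 to compound 4 is therefore expected to be small, no change at the digits printed from compound 3 to compound 4 (within the scatter). Compound 4 is estimated at 27%, between 15% and 40%.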

Compound 4, a percentage reported as inhibition, at one concentration (the size of the read-out at that concentration, not a potency): 20%
The estimate for compound 4 lay 7 percentage points above the measured number; measured number inside the range.
By their numbers in this assay, from the lowest: compounds 4, 2, 3 and 1 (each within the scatter of the next, the first and the last beyond it).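

In this assay the change to 2-nitrophenyl on this aromatic carbon can be read against two other groups (a number 7 percentage points lower from compound 3 to compound 4 (within the scatter)) and (a number 6 percentage points lower from compound 2 to compound 4 (within the scatter)), and neither step separates it from 2,4-dimethoxyphenyl or thiophen-2-yl. Among the compounds shown here, compound 4 (20%) and compound 1 (35%) are nevertheless the first pair here whose gap goes beyond the scatter, so the group at this position can matter to some degree.

No available measurement explains these numbers. Every group shown here is an aromatic ring, so an amine, a carboxylic acid or a longer chain at this position remains an open case.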